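Methyl for fluoro on the anilide ring: expected acidity

The source may report more compounds than this note shows. Statements on the series, on what has been measured and on what is new or still open speak of the compounds shown alone.

Working notes on a small cyanohydroxyimino-acetanilide series. The shared core carries the nitrile, the oxime and the amide, and the compounds differ only in what sits on the aromatic ring of the anilide.

Compound 1 `N#C/C(=N\O)C(=O)Nc1ccc(F)cc1` gives 5.01 in a physicochemical assay for acid dissociation, using potentiometric titration. Compound 2 `N#C/C(=N\O)C(=O)Nc1ccccc1F` gives 4.87 in this assay, and compound 3 `N#C/C(=N\O)C(=O)Nc1cc(F)cc(F)c1` gives 4.81. Among the measured compounds shown here, compound 1 carries the numerically greatest of the three values, but compound 2 and compound 3 both fall within the usual scatter of it, so the three compounds do not separate in this assay, and no step between them is counted.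

The next compound, compound 4 `Cc1ccc(NC(=O)/C(C#N)=N/O)cc1`, differs from compound 1 as follows: methyl in place of fluoro on an aromatic carbon. For the measured compounds named here, no measured pair shows this kind of change, so there is nothing here to set its size from directly. The expectation for compound 4 is a small move towards a higher number, of about a number 0.24 log units higher from compound 1 to compound 4 (within the scatter), possibly still inside the scatter. Compound 4 is therefore estimated at 5.25, with a range from 4.95 to 5.55.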

Compound 4, acid dissociation constant: 5.07
Compound 4: the middle estimate sits 0.18 log units above what was measured; the measured number falls inside the stated range.
By their numbers in this assay, from the lowest: compounds 3, 2, 1 and 4 (each within the scatter of the next).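

Methyl in place of fluoro on an aromatic carbon, para to a group of 8 heavy atoms, gives a number 0.06 log units higher from compound 1 to compound 4 (within the scatter) in this assay, so this change at this position does not separate the two compounds. Among the compounds shown here, compound 1 and compound 4 form the only pair that differs in one place, and they give this change a measured size, which the earlier compounds could not provide. Nothing measured here bears on why the step has this size.

Going by these compounds, it remains open whether an amine or a carboxylic acid on this same aromatic carbon would give a step beyond the scatter from compound 1. The compounds shown also leave open whether methyl in place of fluoro would give a similarly small step from compound 2 or compound 3.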